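Methoxymethyl to methyl on the aryl of compound 1

The source may report more compounds than this note shows. Statements on the series, on what has been measured and on what is new or still open speak of the compounds shown alone.

Compound 1 `CCc1nn2c(-c3c(COC)cc(OC)cc3OC)cccc2c1N(CC1CCOCC1)CC1CC1` and compound 2 `CCCN(CC1CCOCC1)c1c(CC)nn2c(-c3c(OC)cc(COC)cc3OC)cccc12` share one core. In an assay on HEK293 cells for displacement of a labelled ligand from corticotropin-releasing factor receptor 1 (Homo sapiens), read by scintillation counting, with a stated time of 2 h (a higher number here means a weaker inhibitor, a lower number a stronger inhibitor), compound 1 gives 120 nM and compound 2 gives 90 nM; compound 1 holds the higher of the two numbers, yet its gap to compound 2 lies within the scatter. Compound 3 `CCc1nn2c(-c3c(C)cc(OC)cc3OC)cccc2c1N(CC1CCOCC1)CC1CC1` differs from compound 1 by hydrogen in place of methoxy on a saturated chain carbon bound to an aromatic carbon. Among the compounds with values here, no measured pair informs this change. A small step toward a lower number is expected, a 1.8-fold lower number from compound 1 to compound 3 (0.27 log units; within the scatter), possibly not beyond the scatter. Compound 3 is estimated at 65 nM in this assay, between 20 nM and 200 nM.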

Compound 3, half-maximal inhibitory concentration: 40 nM
Estimate against measurement, compound 3: 1.6-fold (0.21 log units) above; low and high end bracket the measured number.
By their numbers in this assay, from the lowest: compound 3; then compounds 2 and 1 (each within the scatter of the next).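

Methoxymethyl to methyl gives the first single-place comparison in the series: in this assay it gives a 3.0-fold lower number from compound 1 to compound 3 (0.48 log units; beyond the scatter) and the step lies beyond the scatter. The methoxy on this saturated chain carbon is therefore not needed to hold the number at the level of compound 1. No measurement on hand accounts for this step.

Open, going by these compounds, is whether ethyl, a longer chain, hydroxymethyl or aminomethyl would hold or lower the number at this place. Also open, on these data alone, is whether the same change in compound 2 would give a similar step.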